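The compounds below may be only part of what the source reports. "The series", "measured", "known", "first", "only" and "open" are said of these compounds alone.

Of the compounds shown here, three sharing one core have been measured in a functional assay on NCI-H460 cells (Homo sapiens) for inhibition, read by sulforhodamine B assay, with a stated time of 48 h; on this read-out higher numbers stand for weaker inhibition of growth and lower numbers for stronger inhibition of growth. Compound 1 `CCOC(=O)[C@H](CCC(=O)O)NC(=O)c1ccc(Oc2nc3cc(N)cc(N)c3nc2-c2ccccc2)cc1` gives 95500 nM. Compound 2 `Nc1cc(N)c2nc(-c3ccccc3)c(NCc3ccc(F)cc3)nc2c1` gives 4070 nM. Compound 3 `COc1ccc(Sc2nc3cc(N)cc(N)c3nc2-c2ccccc2)cc1` gives 20000 nM, which places it second highest of the three: the step of a 4.9-fold higher number from compound 2 to compound 3 (0.69 log units; beyond the scatter) is modest but beyond the scatter, and compound 1 sits a comparable distance higher still.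

Compound 4 `Nc1cc(N)c2nc(-c3ccccc3)c(Sc3ccc(F)cc3)nc2c1` has not yet been measured in this assay. It differs from compound 3 by fluoro in place of methoxy on an aromatic carbon, the change sitting para to a large group on the six-membered ring. Going by the values given here, the only measured step, from compound 2 to compound 3, exchanges the whole (4-fluorobenzyl)amino group for (4-methoxyphenyl)sulfanyl and therefore does not address a methoxy-to-fluoro swap on its own; no measured pair isolates that change. With nothing in the data to point either way, compound 4 is expected to stay close to compound 3, the step of a 1.1-fold lower number from compound 3 to compound 4 (0.05 log units; within the scatter) being estimated to fall within the usual scatter. Compound 4 is thus expected to give about 18000 nM, in a range from 6000 nM to 55000 nM.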

Compound 4, concentration for 50% growth inhibition: 21900 nM
Beside the measured number, compound 4's estimate is 1.2-fold (0.09 log units) below it; the range from low to high includes it.
By their numbers in this assay, from the lowest: compound 2; then compounds 3 and 4 (each within the scatter of the next); then compound 1.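

In this assay, going by these compounds alone, the change from (4-methoxyphenyl)sulfanyl to (4-fluorophenyl)sulfanyl gives a 1.1-fold higher number from compound 3 to compound 4 (0.04 log units; within the scatter), the first isolated reading of fluoro in place of methoxy at this place, and it leaves the two compounds indistinguishable. The step of a 5.4-fold higher number from compound 2 to compound 4 (0.73 log units; beyond the scatter) has a fluoro group on both sides and remains beyond the scatter, so the distance from compound 2 that appeared with the methoxy group in a 4.9-fold higher number from compound 2 to compound 3 (0.69 log units; beyond the scatter) also appears without it. No supporting evidence is available to explain either step.

Going by these compounds, it remains open whether an amine, a carboxylic acid or a longer chain in place of the fluoro group would shift the number. A (4-fluorophenyl)amino or (4-fluorobenzyl)sulfanyl group could also show how much of the distance from compound 2 goes with the linking atom and how much with the benzyl carbon.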